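From 3,4-Dichlorophenyl to 2-Chlorophenyl: An Expected Step

This account rests on a few compounds, and the source may have more. Where it says the series, first, only, none or still open, it means among the compounds named here.

Compound 1 `CC1CC(=O)N(CC(=O)N2CCN(c3ccc(Cl)c(Cl)c3)CC2)C1=O` is the weakest of three measured compounds in a functional assay on the whole organism (strain CD1) with Mus musculus as the target, in the maximal electroshock model, with a stated time of 0.5 h; on this read-out higher numbers stand for an effect only at larger amounts of compound and lower numbers for an effect already at smaller amounts; compound 1 gives 300 mg/kg. Compound 2 `CC1CC(=O)N(CC(=O)N2CCN(c3cccc(C(F)(F)F)c3)CC2)C1=O` gives 100 mg/kg, and compound 3 `CCC1(C)CC(=O)N(CC(=O)N2CCN(c3ccccc3C)CC2)C1=O` gives 100 mg/kg, and the gap from compound 1 to each of them lies beyond the usual scatter, so compound 1 needs a larger dose than either. Compound 4 `CC1CC(=O)N(CC(=O)N2CCN(c3ccccc3Cl)CC2)C1=O` differs from compound 1 in a single place: 2-chlorophenyl in place of 3,4-dichlorophenyl on an amine nitrogen in a ring. Among the measured compounds shown here, no measured pair shows this change, but the two other measured compounds stand at lower numbers, so a move toward a lower number seems likely rather than none. The step from compound 1 to compound 4 is expected to be a 3.0-fold lower number from compound 1 to compound 4 (0.48 log units; beyond the scatter). Compound 4 is therefore estimated at 100 mg/kg, with a range from 50 mg/kg to 300 mg/kg.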

Compound 4, minimum effective dose: 300 mg/kg
For compound 4 the middle estimate is 3.0-fold (0.48 log units) below the measured one; low and high end bracket the measured number.
By their numbers in this assay, from the lowest: compounds 2 and 3 (each within the scatter of the next); then compounds 1 and 4 (each within the scatter of the next).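

In this assay, 2-chlorophenyl in place of 3,4-dichlorophenyl gives no change at the digits printed from compound 1 to compound 4 (within the scatter). Among the compounds shown here, this is the first direct reading of a single change at this place on the shared core, and here the read-out does not separate these two chlorinated phenyl groups, even though one chlorine leaves. No supporting data explain this result. On these data alone, it remains open whether an unsubstituted phenyl, a methoxy group or an amine on the phenyl ring would change the dose needed on this core.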